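Aryl substituent on the semicarbazone: nitro analogue of compound 3

A few compounds are considered here, and "the series" means these few. Any claim that something is new, unique, unknown or untested is made for them only; others in the source may bear on it.

Measured so far in a functional assay on a cell-free system (plasma) for agonist activity at thromboxane A2 receptor (Homo sapiens); a higher number here means a weaker inhibitor, a lower number a stronger inhibitor:
compound 1, `O=C(O)COC/C=C1/C[C@H]2C[C@@H](O)[C@H](/C=N/NC(=O)Nc3cccc(Cl)c3)[C@H]2C1`: compound 1 gives 180 nM
compound 2, `O=C(O)CC/C=C1/C[C@H]2C[C@@H](O)[C@H](/C=N/NC(=O)Nc3ccc([N+](=O)[O-])cc3)[C@H]2C1`: compound 2 gives 20 nM
compound 3, `O=C(O)COC/C=C1/C[C@H]2C[C@@H](O)[C@H](/C=N/NC(=O)Nc3ccccc3)[C@H]2C1`: compound 3 gives 1400 nM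

Compound 3 stands highest of the three numbers in this assay; the nearest is compound 1, the furthest compound 2. For the measured compounds named here, the one single-point step measured, a 7.8-fold higher number from compound 1 to compound 3 (0.89 log units; beyond the scatter), shows that removing the chloro from the aromatic ring raises the number well beyond the scatter.

Compound 4, `O=C(O)COC/C=C1/C[C@H]2C[C@@H](O)[C@H](/C=N/NC(=O)Nc3ccc([N+](=O)[O-])cc3)[C@H]2C1`, differs from compound 3 in one place: nitro in place of hydrogen on an aromatic carbon. Going by the values given here, only the step from compound 1 to compound 3 bears on this change directly, and it describes a ring substituent going out rather than coming in. Compound 2 carries the same nitro group but on a different chain, so no single-point comparison with compound 3 exists; its number is simply far lower than that of compound 3.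

Putting a substituent back onto the ring is therefore expected to lower the number in this assay, by a step of roughly the size seen for the chloro, so compound 4 is expected to give 120 nM, within 35 nM to 450 nM. This estimate means a 12-fold lower number from compound 3 to compound 4 (1.07 log units; beyond the scatter).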

Compound 4, half-maximal inhibitory concentration: 20 nM
Beside the measured number, compound 4's estimate is 6.0-fold (0.78 log units) above it, and the stated range ends above it.
By their numbers in this assay, from the lowest: compounds 2 and 4 (each within the scatter of the next); then compound 1; then compound 3.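

In this assay, the nitro group para to a large group gives a 70-fold lower number from compound 3 to compound 4 (1.85 log units; beyond the scatter), and the swap of 3-chlorophenyl for 4-nitrophenyl still gives a 9.0-fold lower number from compound 1 to compound 4 (0.95 log units; beyond the scatter), so the number at this aromatic position depends on which substituent is present and where, not merely on whether the ring carries one. With 4-nitrophenyl held constant, the chain change gives no change at the digits printed from compound 2 to compound 4 (within the scatter), so carboxymethoxy and carboxymethyl cannot be told apart in this pair. No measurement available here bears on the cause of the nitro step.

The step between compound 1 and compound 4 alters both the group and its place on the ring, so the two contributions remain unseparated. Going by these compounds, whether an amine or a nitrile in the place of the nitro would give a similar number remains open.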